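Shortening the acyl chain of compound 1 by two carbons

The source may hold more compounds than are shown below. What is called first, only, known or untested is meant among the compounds shown, and "the series" means these compounds.

Measured so far:
- Compound 1 `CCCCCCCCCCCCCCCCSCC(COP(=O)(O)OP(=O)(O)OC[C@H]1OC(n2ccc(N)nc2=O)[C@@H](O)[C@@H]1O)OC(=O)CCCCCCCCCCCCCCC`: 200000 nM
- Compound 2 `CCCCCCCCCCCCCCSCC(COP(=O)(O)OP(=O)(O)OC[C@H]1OC(n2ccc(N)nc2=O)[C@@H](O)[C@@H]1O)OC(=O)CCCCCCCCCCC`: > 50000000 nM
- Compound 3 `CCCCCCCCCCCCCCCC(=O)OC(COP(=O)(O)OP(=O)(O)OC[C@H]1OC(n2ccc(N)nc2=O)[C@@H](O)[C@@H]1O)CSCCCCCCCCCCCCCC`: 1500000 nM

Three compounds share one core and differ only in the length of their two long chains. In an ADME assay for solubility (a higher number here means a more soluble compound, a lower number a less soluble compound), compound 1 gives 200000 nM, the lowest of the two numbers reported. Compound 3 gives 1500000 nM in this assay. Compound 2 reaches only a limit of this assay, > 50000000 nM, as noted in the limit of > 50000000 nM in this assay, at which 1 of the 3 values shown sits.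

Compound 4 `CCCCCCCCCCCCCCCCSCC(COP(=O)(O)OP(=O)(O)OC[C@H]1OC(n2ccc(N)nc2=O)[C@@H](O)[C@@H]1O)OC(=O)CCCCCCCCCCCCC` is to be measured. It differs from compound 1 by hydrogen in place of ethyl on a saturated chain carbon, ten or more bonds along the chain from a carbonyl carbon. Among the measured compounds shown here, two measured steps bear on this. The first, a 7.5-fold higher number from compound 1 to compound 3 (0.88 log units; beyond the scatter), removed the same ethyl from the other chain. The second, an at least 33-fold lower number from compound 2 to compound 3 (1.52 log units; beyond the scatter), lengthened the acyl chain and lowered the number. Both point the same way: a shorter chain gives a higher number. A modest rise is therefore expected, a 7.5-fold higher number from compound 1 to compound 4 (0.88 log units; beyond the scatter). Compound 4 is estimated at 1500000 nM, with a range from 400000 nM to 6000000 nM.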

Compound 4, solubility: > 53000000 nM
Compound 4: only a limit was reported (the forecaster's own chance of this, stated with the estimate: 5%); at least 35-fold (1.54 log units) between middle value and limit.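

In this assay, hydrogen in place of ethyl on the chain carrying the carbonyl gives an at least 260-fold higher number from compound 1 to compound 4 (2.42 log units; beyond the scatter), whereas the same change on the chain carrying the sulfur gave a 7.5-fold higher number from compound 1 to compound 3 (0.88 log units; beyond the scatter). The same small trim therefore counts for far more at this position than on the other chain. For compound 4 the result is a limit and not a number, so the true size of its step cannot be read: the limit of > 53000000 nM in this assay, at which 1 of the 4 values shown sits.

As far as these compounds go, compound 2 and compound 4 cannot be put in order, since compound 2 also ends at a limit: the limit of > 50000000 nM in this assay, at which 1 of the 4 values shown sits. What an amine or a carboxylic acid in place of ethyl would do at this position also stays open.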